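The source may hold more compounds than are shown below. What is called first, only, known or untested is meant among the compounds shown, and "the series" means these compounds.

Of the compounds shown here, three have been tested so far, all in an assay for inhibition of histone-lysine N-methyltransferase, H3 lysine-79 specific (Homo sapiens), read by luminescence, with a stated time of 1 h; a higher number here means a weaker inhibitor, a lower number a stronger inhibitor. Compound 1 `Nc1nccc2cc(CNC(=O)Cn3cnc(C(=O)NC4CCCCC4)n3)ccc12` gives > 100000 nM in this assay, which is a limit of the measurement rather than a number. Compound 2 `Nc1ncnc2c1ccn2CCNC(=O)Cn1cnc(C(=O)NC2CCCCC2)n1` likewise gives > 100000 nM in this assay, again only a limit. Compound 3 `O=C(Cn1cnc(C(=O)NC2CCCCC2)n1)NCc1ccc2[nH]ncc2c1` also gives > 100000 nM in this assay, once more a limit and not a number. Compound 3 therefore stands with the other two at the limit of > 100000 nM in this assay, at which 3 of the 3 values shown sit, and no value among the three can be placed above or below another.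

The next compound, compound 4 `CC(C)(C)c1ccc(NC(=O)c2ncn(CC(=O)NCc3ccc4[nH]ncc4c3)n2)cc1`, differs from compound 3 in one place: 4-(tert-butyl)phenyl in place of cyclohexyl on an amide-type nitrogen. No step between two measured compounds is available to show what a change of this kind does in this assay, so the expected size of the step rests only on the limits shown. From compound 3 to compound 4 the expected step is a number no higher from compound 3 to compound 4 (the limit leaves the size open), that is, no change beyond the scatter. Compound 4 is therefore estimated at 100000 nM in this assay, with a likely range from 30000 nM to 300000 nM, and most likely another limit rather than a number.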

Compound 4, half-maximal inhibitory concentration: 22400 nM
Compound 4: the middle estimate sits 4.5-fold (0.65 log units) above what was measured; the whole stated range lies above it.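

This position on the amide-type nitrogen clearly matters: in this assay, 4-(tert-butyl)phenyl in place of cyclohexyl gives an at least 4.4-fold lower number from compound 3 to compound 4 (0.64 log units; beyond the scatter). The step is a minimum rather than an exact size, since its starting point is only a limit. This is the first change shown that brings a compound within measurable range, leaving compound 4 as the only one with a true number: the limit of > 100000 nM in this assay, at which 3 of the 4 values shown sit.

On these data alone, whether the gain comes from the aromatic ring or from the tert-butyl group stays open, and a plain phenyl on this nitrogen would help separate the two. Also open, as far as these compounds go, is how an amine or a carboxylic acid in place of the tert-butyl group would read, and whether the same change would have a similar effect on the cores of compound 1 and compound 2.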